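Swapping chloro for methyl on the sulfonyl-linked ring

This account rests on a few compounds, and the source may have more. Where it says the series, first, only, none or still open, it means among the compounds named here.

Three compounds share one core and were measured in an assay on isolated protein for displacement of a labelled ligand from metabotropic glutamate receptor 5 (Homo sapiens), with a stated time of 60 min, tested at 1 uM; on this read-out higher numbers stand for more inhibition at the one concentration tested (going by the name of the read-out) and lower numbers for less inhibition. Compound 1, `COc1ccc2ncc(S(=O)(=O)c3ccc(Cl)c(Cl)c3)c(N3CCC(C)CC3)c2c1`, gives 87%. Compound 2, `CC1CCN(c2c(S(=O)(=O)c3ccc(Cl)c(Cl)c3)cnc3ccc(Cl)cc23)CC1`, gives 86%. Compound 3, `CC1CCN(c2c(S(=O)(=O)c3ccc(Cl)c(Cl)c3)cnc3ccc(F)cc23)CC1`, gives 91%, the highest of the three numbers, though the gaps to the others are small: a number 4 percentage points higher from compound 1 to compound 3 (within the scatter) and a number 5 percentage points higher from compound 2 to compound 3 (within the scatter), and likewise a number 1 percentage points lower from compound 1 to compound 2 (within the scatter). All three steps are within the scatter, so the three compounds cannot be put in any order.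

Compound 4, `Cc1ccc(S(=O)(=O)c2cnc3ccc(F)cc3c2N2CCC(C)CC2)cc1Cl`, differs from compound 3 in one place: methyl in place of chloro on an aromatic carbon. Within the data shown here, none of the measured steps touches this ring; they all alter a group on a different part of the core, and each stayed within the scatter. There is therefore no measured step that bears on this change, and no reason from the data to expect movement beyond the scatter. The expectation is a number 5 percentage points lower from compound 3 to compound 4 (within the scatter), essentially no change, and compound 4 is estimated at 86%, between 66% and 96%.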

Compound 4, a percentage reported as inhibition, at one concentration (the size of the read-out at that concentration, not a potency): 91%
For compound 4 the middle estimate is 5 percentage points below the measured one; the measured number falls inside the stated range.
By their numbers in this assay, from the lowest: compounds 2, 1, 3 and 4 (each within the scatter of the next).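

Among these compounds, compound 4 gives the first reading on the sulfonyl-linked ring, as every earlier step altered a group elsewhere on the core. In this assay, going from 3,4-dichlorophenyl to 3-chloro-4-methylphenyl gives no change at the digits printed from compound 3 to compound 4 (within the scatter), so at this one position, methyl can take the place of chloro with no movement beyond the scatter at the single concentration tested, although a reading at one concentration is not a potency. Nothing measured here offers an explanation for this result.

Still open, going by these compounds, is whether an amine, a carboxylic acid or a longer chain such as propyl at this position would also stay within the scatter of compound 4. On these data alone, it is also open whether the same swap would give a similar reading with the methoxy of compound 1 or the chloro of compound 2 on the core.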